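The compounds below may be only part of what the source reports. "The series", "measured", "known", "first", "only" and "open" are said of these compounds alone.

Compound 1 `S=c1oc(-c2ccc3c(c2)OCCO3)nn1CN1CCN(c2ccc(Cl)cc2)CC1`: in a functional assay on SW 1116 cells (Homo sapiens) for antiproliferative activity, read by MTT assay, with a stated time of 48 h (a higher number here means a weaker inhibitor, a lower number a stronger inhibitor), compound 1 gives > 50000 nM, which is a limit of the assay rather than a number.
Compound 2 `S=c1oc(-c2ccc3c(c2)OCCO3)nn1CN1CCN(c2ccccc2)CC1`: in this assay compound 2 gives > 50000 nM, again a limit.
Compound 3 `COc1ccccc1N1CCN(Cn2nc(-c3ccc4c(c3)OCCO4)oc2=S)CC1`: in this assay compound 3 gives 16900 nM.

Among the measured compounds shown here, compound 3 therefore stands at the only number in the set, the other two values being limits, as the limit of > 50000 nM in this assay, at which 2 of the 3 values shown sit, records. Compound 4 `Fc1ccc(N2CCN(Cn3nc(-c4ccc5c(c4)OCCO5)oc3=S)CC2)cc1` differs from compound 3 by 4-fluorophenyl in place of 2-methoxyphenyl on an amine nitrogen in a ring. For the measured compounds named here, two measured steps bear on this change. Going by the values given here, the step from compound 1 to compound 3, an at least 2.9-fold lower number from compound 1 to compound 3 (0.47 log units; beyond the scatter), and the step from compound 2 to compound 3, an at least 2.9-fold lower number from compound 2 to compound 3 (0.47 log units; beyond the scatter), both run toward the 2-methoxyphenyl compound, so the methoxy on the aromatic carbon is tied to the only readable number. The step that the two limits leave unreadable from compound 1 to compound 2 shows that exchanging chloro for hydrogen on the aromatic carbon cannot be read between the two limits. Since compound 4 gives up the methoxy and carries a halogen on the phenyl, as compound 1 does, the step from compound 3 to compound 4 is expected to run toward a higher number, a 2.7-fold higher number from compound 3 to compound 4 (0.43 log units; beyond the scatter), with a real chance that only a limit is reported. Compound 4 is accordingly estimated at 45000 nM, within a range from 18000 nM to 110000 nM.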

Compound 4, half-maximal inhibitory concentration: > 50000 nM
Compound 4: only a limit was reported (the forecaster's own chance of this, stated with the estimate: 55%); middle value at least 1.1-fold (0.04 log units) away from the limit.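

Placing 4-fluorophenyl where 2-methoxyphenyl stood on the amine nitrogen in a ring gives an at least 2.9-fold higher number from compound 3 to compound 4 (0.47 log units; beyond the scatter), so this exchange at this position costs measurable activity in this assay, and fluoro now joins chloro and hydrogen among the phenyl variants without a readable number. The steps linking compound 4 to compound 1 and compound 2 cannot be read, since all three compounds carry only limits, so no order among the fluoro, chloro and unsubstituted phenyl compounds can be stated. Among the four compounds, only the 2-methoxyphenyl compound, compound 3, gives a number, and none goes against this, while the remaining compounds gather at one value: the limit of > 50000 nM in this assay, at which 3 of the 4 values shown sit.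

The names 2-methoxyphenyl and 4-fluorophenyl differ in both the group and its number on the phenyl, so the step from compound 3 leaves open whether the methoxy group itself or the place it occupies accounts for the gain. The compounds shown also leave open how an ethoxy, a hydroxy or a nitrile on the phenyl, or a pyridine in place of the phenyl, would read in this assay.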